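A chlorophenyl swap on the shared core

A few compounds are considered here, and "the series" means these few. Any claim that something is new, unique, unknown or untested is made for them only; others in the source may bear on it.

Of the compounds shown here, three with one shared core have been measured in a functional assay on B16-F10 cells (Mus musculus) for antiproliferative activity, read by MTT assay, with a stated time of 48 h; on this read-out higher numbers stand for weaker inhibition and lower numbers for stronger inhibition. Compound 1 `COc1ccc(C2OC(c3ccc4ccccc4c3)=NN2C(C)=O)cc1` gives 6.86 ug/mL, compound 2 `CC(=O)N1N=C(c2ccc3ccccc3c2)OC1c1ccc(Br)cc1` gives 4.68 ug/mL, and compound 3 `CC(=O)N1N=C(c2ccc3ccccc3c2)OC1c1ccccc1Cl` gives 4.93 ug/mL. Compound 3 shows no separation from either of the others: a 1.1-fold higher number from compound 2 to compound 3 (0.02 log units; within the scatter) and a 1.4-fold lower number from compound 1 to compound 3 (0.14 log units; within the scatter) both stay within the scatter, as does a 1.5-fold lower number from compound 1 to compound 2 (0.17 log units; within the scatter).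

The next compound, compound 4 `CC(=O)N1N=C(c2ccc3ccccc3c2)OC1c1ccc(Cl)cc1`, has the same atoms as compound 3, joined differently: 4-chlorophenyl in place of 2-chlorophenyl on a saturated ring carbon. Going by the values given here, no measured pair isolates this swap, since none holds the halogen fixed and moves only its place on the phenyl ring. The nearest evidence is a 1.1-fold higher number from compound 2 to compound 3 (0.02 log units; within the scatter), which exchanges 4-bromophenyl for 2-chlorophenyl at this same saturated ring carbon and stays within the scatter. The wider exchange in a 1.4-fold lower number from compound 1 to compound 3 (0.14 log units; within the scatter), from 4-methoxyphenyl, also stays within it. On this evidence, no step beyond the scatter is expected in this assay, and neither direction is favoured. The expected size is a 1.0-fold lower number from compound 3 to compound 4 (0.02 log units; within the scatter). Among the compounds with values here, with only three measured neighbours, the range is kept wide. For compound 4 the estimated value is 4.7 ug/mL, with an expected range of 2.7 ug/mL to 8 ug/mL.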

Compound 4, half-maximal inhibitory concentration: 2.48 ug/mL
The estimate for compound 4 lay 1.9-fold (0.28 log units) above the measured number, and the stated range ends above it.
By their numbers in this assay, from the lowest: compounds 4, 2, 3 and 1 (each within the scatter of the next, the first and the last beyond it).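

Moving the chlorine, with 4-chlorophenyl in place of 2-chlorophenyl on the saturated ring carbon, gives a 2.0-fold lower number from compound 3 to compound 4 (0.30 log units; within the scatter) in this assay, and chloro in place of bromo on an aromatic carbon gives a 1.9-fold lower number from compound 2 to compound 4 (0.28 log units; within the scatter), so neither the place of the chlorine nor the choice between these two halogens separates these compounds in this assay. Going by these compounds alone, the one step that passes the scatter is a 2.8-fold lower number from compound 1 to compound 4 (0.44 log units; beyond the scatter), a modest separation that comes with a chloro group where compound 1 carries a methoxy group, whereas compound 2 and compound 3 each stay within the scatter of compound 1. No measurement among these data offers an explanation for this separation.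

The compounds shown leave open whether the separation from compound 1 is particular to chloro, or whether fluoro, an amine or a carboxylic acid on the same phenyl ring would give a similar number. They also leave open how the numbers in this assay would respond to a longer chain in place of the acetyl group on the shared core.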